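The source may report more compounds than this note shows. Statements on the series, on what has been measured and on what is new or still open speak of the compounds shown alone.

Measured compounds:
compound 1, `Cc1c(OCCCCOc2ccc(C(=O)CC(C)(C)C)c(O)c2C)cccc1C(=O)O`, giving 95.8%
compound 2, `Cc1c(OCCCCOc2cccc(C(=O)O)c2)ccc(C(=O)CC(C)C)c1C`, giving 12.1%

In an assay on HEK293 cells for positive allosteric modulation of metabotropic glutamate receptor 2 (Rattus norvegicus), read by thallium flux, with a stated time of 2.5 min (on this read-out lower numbers stand for smaller maximal responses and higher numbers for larger maximal responses), compound 1 reaches 95.8%, whereas compound 2 reaches only 12.1%. Compound 2 therefore stands at the lower of the two numbers, and its gap to compound 1 is well beyond the scatter of the assay.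

Compound 3, `Cc1c(OCCCCOc2cccc(C(=O)O)c2)ccc(C(=O)CC(C)C)c1O`, has not been measured. It differs from compound 2 in one place: hydroxy in place of methyl on an aromatic carbon. With this change compound 3 carries a hydroxy on the ketone-bearing ring, as compound 1 does, and compound 1 gives 95.8%.

For compound 3 an increase in this assay is expected, with a step of a number 47.9 percentage points higher from compound 2 to compound 3 (beyond the scatter) that should lie beyond the scatter. The estimate for compound 3 is 60%, within a range from 20% to 95%.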

Compound 3, largest response reached (reported as percent of maximum), in percent of the reference or control that the assay uses: 84.5%
Compound 3: middle estimate off by 24.5 percentage points, on the low side; low and high end bracket the measured number.
By their numbers in this assay, from the lowest: compound 2; then compound 3; then compound 1.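

In this assay, within the data shown here, the single exchange of hydroxy for methyl gives a number 72.4 percentage points higher from compound 2 to compound 3 (beyond the scatter), with the rest of the structure unchanged. Compound 1 and compound 2 differ in more than one place, so their gap could not be assigned to any one of them, whereas this pair ties a large change in maximal response to this aromatic carbon, ortho to an isobutylcarbonyl group. Nothing measured here accounts for the size of the step.

The compounds shown leave open whether a methoxy group, an amine or a fluorine on this carbon would give a response like that of hydroxy. They also leave open whether the step would hold with a longer chain in place of the isobutylcarbonyl group.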